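Cytotoxicity on Vero Cells: From Compound 1 to Compound 4

A few compounds are considered here, and "the series" means these few. Any claim that something is new, unique, unknown or untested is made for them only; others in the source may bear on it.

Compound 1, with structure `C[C@]1(CN2CCc3nc(-c4ccc(OC(F)(F)F)cc4)ccc3C2)Cn2cc([N+](=O)[O-])nc2O1`, has no single number in an ADME assay on Vero cells (Chlorocebus sabaeus) for cytotoxicity, read by MTT assay, with a stated time of 72 h; on this read-out higher numbers stand for lower toxicity in this test and lower numbers for higher toxicity in this test; for compound 1 the outcome in this assay is recorded as "not determined" (no result reported). Two related compounds stand beside it. For the measured compounds named here, compound 2, with structure `C[C@]1(CN2CCc3nc(-c4ccc(F)c(F)c4)oc3C2)Cn2cc([N+](=O)[O-])nc2O1`, is the only one with a reading, and that reading is a limit of the assay rather than a number: in this assay compound 2 gives > 32 ug/mL. Compound 3, with structure `C[C@]1(CN2CCn3nc(-c4ccc(F)c(F)c4)nc3C2)Cn2cc([N+](=O)[O-])nc2O1`, is recorded in this assay as "not determined" (no result reported). So the only evidence to go on is the limit of > 32 ug/mL in this assay, at which 1 of the 3 values shown sits.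

Compound 4, with structure `C[C@]1(CN2CCc3nc(-c4cc(F)cc(F)c4)ccc3C2)Cn2cc([N+](=O)[O-])nc2O1`, differs from compound 1 by a change on the shared core: 3,5-difluorophenyl in place of 4-(trifluoromethoxy)phenyl on an aromatic carbon. Going by the values given here, no measured step between these compounds exists in this assay, so the account can only say that no shift beyond the usual scatter is expected from this replacement, in either direction. On that basis compound 4 is expected to sit at about 40 ug/mL in this assay, within a range from 16 ug/mL to 100 ug/mL, most likely again reported only as a limit.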

Compound 4, half-maximal cytotoxic concentration: > 32 ug/mL
Compound 4: a limit, no number; the forecaster's own chance of this, stated with the estimate: 70%; the middle value is on the limit's open side.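

In this assay compound 4 gives > 32 ug/mL, which is a limit of the assay and not a number. For the compounds shown here, compound 1 has no single number, so no step from compound 1 to compound 4 can be read. The compounds shown leave open whether 3,5-difluorophenyl in place of 4-(trifluoromethoxy)phenyl shifts the half-maximal cytotoxic concentration at all.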